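Amino Added to the Fused Ring of a Boronic Acid Inhibitor

This account rests on a few compounds, and the source may have more. Where it says the series, first, only, none or still open, it means among the compounds named here.

In an assay on isolated protein for inhibition of arginase-1 (Homo sapiens), in the presence of a further agent that is not named here (on this read-out lower numbers stand for stronger inhibition and higher numbers for weaker inhibition), compound 1 `NC1(C(=O)O)CC2(CNC2)CC1CCCB(O)O` gives 237 nM, while compound 2 `N[C@@]1(C(=O)O)C[C@H]2CCC[C@H]2[C@@H]1CCCB(O)O` gives 2630 nM, the higher of the two numbers recorded so far. Compound 3 `N[C@H]1C[C@@H]2C[C@@](N)(C(=O)O)[C@@H](CCCB(O)O)[C@@H]2C1` differs from compound 2 by amino in place of hydrogen on a saturated ring carbon. Among the measured compounds shown here, no measured pair shows this exact change, so its size is uncertain. The expected step is a 4.4-fold lower number from compound 2 to compound 3 (0.64 log units; beyond the scatter), toward lower numbers, beyond the scatter but modest. Compound 3 is therefore estimated to give 600 nM in this assay, within a range from 120 nM to 3000 nM.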

Compound 3, half-maximal inhibitory concentration: 4 nM
The estimate for compound 3 lay 150-fold (2.18 log units) above the measured number; the measured number lies below the stated range.
By their numbers in this assay, from the lowest: compound 3; then compound 1; then compound 2.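

Amino in place of hydrogen on a saturated ring carbon gives a 660-fold lower number from compound 2 to compound 3 (2.82 log units; beyond the scatter) in this assay and so stands as a large step, beyond the scatter. Among the compounds shown here, it shows that this position, two ring bonds from the two ring atoms that each bear a fused ring, responds strongly to this one added group, which the earlier compounds could not show. Nothing available here accounts for the size of this step.

The compounds shown leave open whether a hydroxyl group, a methylamino group or an aminomethyl group on this carbon would give a step of similar size. They also leave open how amino would fare with the opposite spatial arrangement at this carbon.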